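The source may report more compounds than this note shows. Statements on the series, on what has been measured and on what is new or still open speak of the compounds shown alone.

Working notes on this series. The parent, compound 1 `O=C(Nc1ccccc1)C(Cl)Cl`, is measured in a functional assay on A549 cells (Homo sapiens) for antiproliferative activity, read by MTT assay, with a stated time of 72 h (on this read-out lower numbers stand for stronger inhibition and higher numbers for weaker inhibition), where compound 1 gives 130000 nM. Within this set compound 1 stands with the highest of the two numbers reported; the nearest entry is compound 2 `Cc1cccc(NC(=O)C(Cl)Cl)c1`, which in this assay gives 41100 nM. Compound 3 `O=C(Nc1cccc(NC(=O)C(Cl)Cl)c1)C(Cl)Cl`, the bis-amide, has no result reported in this assay, where compound 3 stands as "not determined" (no result reported), so it adds nothing to the comparison.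

For the measured compounds named here, the only step that can be measured is a 3.2-fold lower number from compound 1 to compound 2 (0.50 log units; beyond the scatter), a methyl in place of hydrogen on an aromatic carbon, which moves the number beyond the scatter but only modestly.

Compound 4 `O=C(Nc1ccc(Cl)cc1)C(Cl)Cl` differs from compound 1 by chloro in place of hydrogen on an aromatic carbon. Going by the values given here, no measured pair carries a chloro substituent, so the expectation rests on the single ring-substitution step available. A shift of roughly the same size and direction as from compound 1 to compound 2 is expected; the estimate corresponds to a 2.6-fold lower number from compound 1 to compound 4 (0.41 log units; beyond the scatter). Compound 4 is therefore expected to give about 50000 nM in this assay, with a range from 15000 nM to 160000 nM.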

Compound 4, half-maximal inhibitory concentration: 20400 nM
Beside the measured number, compound 4's estimate is 2.5-fold (0.39 log units) above it; the range from low to high includes it.
By their numbers in this assay, from the lowest: compounds 4 and 2 (each within the scatter of the next); then compound 1.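

In this assay, for the compounds shown here, chloro in place of hydrogen on an aromatic carbon, para to a group of 6 heavy atoms, gives a 6.4-fold lower number from compound 1 to compound 4 (0.80 log units; beyond the scatter) as the first measured step with a halogen and the first at this position. Together with a 3.2-fold lower number from compound 1 to compound 2 (0.50 log units; beyond the scatter) as the methyl step, it makes two ring substitutions on the core of compound 1 that each lower the number, and both steps lie beyond the scatter while remaining modest. No measured property is available to account for the size of the chloro step.

On these data alone, whether other groups at this same place, such as methoxy, an amine or a carboxylic acid, also lower the number remains open. Also open, as far as these compounds go, is whether chloro and methyl together on one ring would add to each other.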